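The source may hold more compounds than are shown below. What is called first, only, known or untested is meant among the compounds shown, and "the series" means these compounds.

Measured in a functional assay on M21 cells (Homo sapiens) for antiproliferative activity, read by sulforhodamine B assay, with a stated time of 48 h; on this read-out lower numbers stand for stronger inhibition and higher numbers for weaker inhibition:
- compound 1 `Cc1ccc(NS(=O)(=O)c2ccc(N3CCNC3=O)cc2)cc1`: 260 nM
- compound 2 `Cc1ccc(NS(=O)(=O)c2ccc(N3CCNC3=O)cc2)cc1C`: 94 nM

Compound 1 at 260 nM holds the higher of the two numbers in this assay. Compound 3 `CCCCCCCc1ccc(NS(=O)(=O)c2ccc(N3CCNC3=O)cc2)cc1` departs from compound 1 by hexyl in place of hydrogen on a saturated chain carbon bound to an aromatic carbon, which turns methyl to heptyl. For the measured compounds named here, one measured step bears on this, a 2.8-fold lower number from compound 1 to compound 2 (0.44 log units; beyond the scatter), a modest change on an aromatic carbon. That step is a small addition at another place, so it guides only weakly. A step to a higher number is expected, with wide uncertainty. The expected move is a 3.8-fold higher number from compound 1 to compound 3 (0.59 log units; beyond the scatter). The estimate for compound 3 is 1000 nM, with an estimated range of 200 nM to 6000 nM.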

Compound 3, half-maximal inhibitory concentration: > 1000 nM
Compound 3: no number, only a limit (the forecaster's own chance of this, stated with the estimate: 10%); the middle value sits exactly at the limit.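

In this assay compound 3 gives > 1000 nM, which is a limit and not a number. The methyl of compound 1, on a saturated chain carbon bound to an aromatic carbon, therefore does not accept extension to heptyl without loss: an at least 3.8-fold higher number from compound 1 to compound 3 (0.58 log units; beyond the scatter). For the compounds shown here, this is the first change to raise the number, though its full size stays unknown.

Open, going by these compounds, is how the number follows chain length between methyl and heptyl, as with ethyl or propyl at this place. Also open, on these data alone, is how a chain ending in an amine or a carboxylic acid would read.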